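The source may report more compounds than this note shows. Statements on the series, on what has been measured and on what is new or still open speak of the compounds shown alone.

Compound 1 `Cc1ccc(-c2nnc(SCCn3c([N+](=O)[O-])cnc3C)o2)cc1` gives 15500 nM in a functional assay on MCF7 cells (Homo sapiens) for cytotoxicity, read by MTT assay, with a stated time of 48 h; a lower number here means a stronger inhibitor, a higher number a weaker inhibitor; it stands highest of the three numbers in hand, though compound 2 `Cc1ncc([N+](=O)[O-])n1CCSc1nnc(-c2ccc([N+](=O)[O-])cc2)o1` with 12700 nM and compound 3 `Cc1ncc([N+](=O)[O-])n1CCSc1nnc(-c2ccc(F)cc2)o1` with 8100 nM both lie within the scatter of it. Compound 4 `Cc1ncc([N+](=O)[O-])n1CCSc1nnc(-c2ccc(Cl)cc2)o1` differs from compound 1 by chloro in place of methyl on an aromatic carbon. For the measured compounds named here, the steps that bear on it are the other changes at the same aromatic carbon: a 1.2-fold lower number from compound 1 to compound 2 (0.09 log units; within the scatter) and a 1.9-fold lower number from compound 1 to compound 3 (0.28 log units; within the scatter), neither beyond the scatter. On that basis no step beyond the scatter is expected, with at most a slight drift toward a lower number, so the step of a 1.6-fold lower number from compound 1 to compound 4 (0.19 log units; within the scatter) is the estimate. Compound 4 is expected to give 10000 nM, within a range of 5000 nM to 25000 nM.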

Compound 4, half-maximal inhibitory concentration: 18700 nM
Compound 4: middle estimate off by 1.9-fold (0.27 log units), on the low side; the range from low to high includes it.
By their numbers in this assay, from the lowest: compounds 3, 2, 1 and 4 (each within the scatter of the next, the first and the last beyond it).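

For the compounds shown here, at this aromatic carbon, chloro and fluoro are the only pair of groups that separate in this assay (a 2.3-fold higher number from compound 3 to compound 4 (0.36 log units; beyond the scatter)), a modest step and the only one beyond the scatter. Chloro does not separate from methyl (a 1.2-fold higher number from compound 1 to compound 4 (0.08 log units; within the scatter)) or from nitro (a 1.5-fold higher number from compound 2 to compound 4 (0.17 log units; within the scatter)). Nothing at hand accounts for the step from fluoro to chloro.

On these data alone, whether an amine or a carboxylic acid at this aromatic carbon would move the number further stays open. So does the effect of any change elsewhere on the shared core.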